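From Ethyl to Butylamino: What Step to Expect

The source may report more compounds than this note shows. Statements on the series, on what has been measured and on what is new or still open speak of the compounds shown alone.

Compound 1, `C=CCOc1ccc(C(=O)Nc2cccc(Cl)n2)cc1`, in an in vitro assay on HEK-tsA201 cells for antagonist activity at Neuronal acetylcholine receptor; alpha4/beta2 (Homo sapiens), read by fluorescence and calcium flux (on this read-out higher numbers stand for weaker inhibition and lower numbers for stronger inhibition), gives only a limit of > 100000 nM.
Compound 2, `C=CCOc1ccc(C(=O)Nc2cccc(CC)n2)cc1`, gives 20500 nM.
Compound 3, `CCCOc1ccc(C(=O)Nc2cccc(CC)n2)cc1`, gives 37600 nM.

Among the two actual numbers, compound 2 has the lowest, and compound 3 stands within the scatter of it. The value of compound 1 is a limit of the assay, not a number. Compound 4, `C=CCOc1ccc(C(=O)Nc2cccc(NCCCC)n2)cc1`, differs from compound 2 by butylamino in place of ethyl on an aromatic carbon. Within the data shown here, two measured steps bear on this. The step of an at least 4.8-fold lower number from compound 1 to compound 2 (0.68 log units; beyond the scatter) shows that the group on this carbon can shift the number by at least a modest amount, and a 1.8-fold higher number from compound 2 to compound 3 (0.26 log units; within the scatter) shows a change elsewhere that stayed within the scatter. Neither step involves butylamino, so its direction cannot be read from the data. Compound 4 is therefore expected near the value of compound 2, estimated at 15000 nM, with a range from 4000 nM to 60000 nM. This estimate means an expected step of a 1.4-fold lower number from compound 2 to compound 4 (0.14 log units; within the scatter), which may well stay within the scatter.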

Compound 4, half-maximal inhibitory concentration: 22400 nM
Compound 4: the middle estimate sits 1.5-fold (0.17 log units) below what was measured; the range from low to high includes it.
By their numbers in this assay, from the lowest: compounds 2, 4 and 3 (each within the scatter of the next). At a limit, above all of these: compound 1.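

Butylamino in place of ethyl on this aromatic carbon, next to the ring nitrogen, gives a 1.1-fold higher number from compound 2 to compound 4 (0.04 log units; within the scatter), so a group of 5 heavy atoms carrying a hydrogen-bond donor and acceptor fits this position as well as the ethyl with its 2 heavy atoms. Compared with chloro, butylamino gives an at least 4.4-fold lower number from compound 1 to compound 4 (0.64 log units; beyond the scatter), so a second, quite different group also lies clear of chloro, as ethyl did. That step is only a bound, because compound 1 stands at a limit: the limit of > 100000 nM in this assay, at which 1 of the 4 values shown sits.

Going by these compounds, whether a plain amine, a shorter alkylamino chain or a carboxylic acid on this carbon would move the number beyond the scatter stays open. So does whether butylamino would give a similar number on the core of compound 3.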